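This account rests on a few compounds, and the source may have more. Where it says the series, first, only, none or still open, it means among the compounds named here.

Compound 1 `O=C(O)c1cccc(-c2ccc(/C=C3\S/C(=N\c4ccc(F)cc4)N(c4ccc(F)cc4)C3=O)s2)c1` and compound 2 `O=C(O)c1cccc(-c2ccc(/C=C3\S/C(=N\c4ccc(Cl)cc4)N(c4ccccc4)C3=O)o2)c1` share a core and carry a carboxylic acid on one aromatic ring. In an ADME assay on Vero cells (Chlorocebus sabaeus) for cytotoxicity (on this read-out higher numbers stand for lower toxicity in this test and lower numbers for higher toxicity in this test), compound 1 gives only a limit, > 200000 nM, not a number. In this assay compound 2 likewise gives only a limit, > 200000 nM. Both therefore sit at the same place, the edge of what this assay can report, as shown by the limit of > 200000 nM in this assay, at which 2 of the 2 values shown sit; no difference between them can be read from these two results. Compound 3 `O=C(O)c1cccc(-c2ccc(/C=C3\S/C(=N\c4ccc(Cl)cc4)N(c4ccccn4)C3=O)o2)c1` has not yet been measured. It differs from compound 2 by one change: pyridin-2-yl in place of phenyl on an amide-type nitrogen in a ring. Among the compounds with values here, no step between measured compounds is available, so the size of the step in this assay from compound 2 to compound 3 is expected to be none beyond the scatter, with the step of a number no higher from compound 2 to compound 3 (the limit leaves the size open). For compound 3 the estimate in this assay is 200000 nM, within 100000 nM to 400000 nM, most likely again reported only as a limit.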

Compound 3, half-maximal cytotoxic concentration: > 200000 nM
Compound 3: only a limit was reported (the forecaster's own chance of this, stated with the estimate: 80%); the middle value lies on the limit itself.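

In this assay compound 3 again gives only a limit, so no step can be read between compound 2 and compound 3: the limit of > 200000 nM in this assay, at which 3 of the 3 values shown sit. The compounds shown leave open whether compound 1, compound 2 and compound 3 differ at all in cytotoxicity, and at what concentration each would harm these cells.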